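This account rests on a few compounds, and the source may have more. Where it says the series, first, only, none or still open, it means among the compounds named here.

Compound 3, with the structure `CCNc1ncnc2c1ncn2Cc1ccccc1F`, is the reference point of this account. In a functional assay on the whole organism with Rattus norvegicus as the target, in the maximal electroshock model (on this read-out lower numbers stand for an effect already at smaller amounts and higher numbers for an effect only at larger amounts of compound), compound 3 gives 4.9 mg/kg, the lowest of the three numbers recorded. The nearest of the others is compound 1, `CNc1ncnc2c1ncn2Cc1cccc(F)c1`, which in this assay gives 7 mg/kg; that gap lies within the scatter, so the two cannot be ranked against each other. The furthest is compound 2, `CNc1ncnc2c1ncn2Cc1ccccc1C`, which in this assay gives 10 mg/kg, a gap that lies beyond the scatter. Compound 1, compound 2 and compound 3 differ from one another in more than one place, so none of these comparisons isolates a single structural change.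

Compound 4, `CN(C)c1ncnc2c1ncn2Cc1ccccc1F`, has not yet been measured. It differs from compound 3 as follows: dimethylamino in place of ethylamino on an aromatic carbon. Within the data shown here, no pair of measured compounds shows this kind of change, so there is no step in the data from which its effect can be read directly. For compound 4 a modest worsening is expected, with the change a 2.4-fold higher number from compound 3 to compound 4 (0.39 log units; beyond the scatter) estimated to fall at or a little beyond the edge of the scatter. Compound 4 is therefore expected to give about 12 mg/kg in this assay, within a range from 5 mg/kg to 30 mg/kg.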

Compound 4, dose for half-maximal effect: 8.8 mg/kg
The estimate for compound 4 lay 1.4-fold (0.13 log units) above the measured number, within the range that was stated.
By their numbers in this assay, from the lowest: compounds 3, 1, 4 and 2 (each within the scatter of the next, the first and the last beyond it).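

Among these compounds, this is the first comparison in the set that isolates a single structural change, and in this assay replacing ethylamino with dimethylamino on this aromatic carbon gives a 1.8-fold higher number from compound 3 to compound 4 (0.25 log units; within the scatter). The two groups have the same heavy-atom count, but dimethylamino carries no hydrogen-bond donor where ethylamino carries one, so for this pair, removing the donor from this position leaves the two numbers unrankable and a number in this range does not depend on that donor. No measurement at hand accounts for this result or links it to any property of the two groups.

The compounds shown leave open how a plain primary amine, a longer chain such as propylamino or a cyclic amine such as pyrrolidine would read at this aromatic carbon, since only the ethylamino and dimethylamino groups can be compared here on one otherwise unchanged structure. This is also a single pair, so whether the exchange of ethylamino for dimethylamino would give a similarly small step on the core of compound 1 or compound 2 remains an open question.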